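The compounds below may be only part of what the source reports. "The series", "measured", "known", "first", "only" and "open" are said of these compounds alone.

Measured compounds in a functional assay on Jurkat cells for inhibition of nuclear factor NF-kappa-B complex (Homo sapiens); on this read-out higher numbers stand for weaker inhibition and lower numbers for stronger inhibition:
compound 1 `CCOC(=O)c1cnc(C(C)(C)C)nc1NN1C(=O)C=C(C)C1=O`: 1000 nM
compound 2 `CCOC(=O)c1cnc(-c2ccccc2)nc1NN1C(=O)C=C(C)C1=O`: 100 nM
compound 3 `CCOC(=O)c1cnc(-c2ccc(F)cc2)nc1NN1C(=O)C=C(C)C1=O`: 700 nM

Among these three numbers compound 3 stands second highest. Its closest neighbour is compound 1, since a 1.4-fold lower number from compound 1 to compound 3 (0.15 log units; within the scatter). Going by the values given here, the only clearly separated value is that of compound 2, as a 7.0-fold higher number from compound 2 to compound 3 (0.85 log units; beyond the scatter).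

Compound 4 `CCOC(=O)c1cnc(-c2cc3ccccc3s2)nc1NN1C(=O)C=C(C)C1=O` has not been measured. It differs from compound 3 in one place: 1-benzothiophen-2-yl in place of 4-fluorophenyl on an aromatic carbon. Two earlier steps speak to this change. First, moving from a non-aromatic group to an aromatic one lowered the number: a 10-fold lower number from compound 1 to compound 2 (1.00 log units; beyond the scatter). Second, the aromatic group without the fluorine gave the lower number, as a 7.0-fold higher number from compound 2 to compound 3 (0.85 log units; beyond the scatter) shows. Among the compounds with values here, compound 4 likewise carries an aromatic group without fluorine, but a larger, two-ring one, and no measured compound shows what such a group does here. On balance a modest decrease in number from compound 3 is expected, toward the value of compound 2 but with wide uncertainty, so the estimated step is a 2.3-fold lower number from compound 3 to compound 4 (0.37 log units; beyond the scatter). For compound 4 in this assay the expected value is 300 nM, estimated to lie between 60 nM and 1500 nM.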

Compound 4, half-maximal inhibitory concentration: 4000 nM
For compound 4 the middle estimate is 13-fold (1.12 log units) below the measured one, and the stated range ends below it.
By their numbers in this assay, from the lowest: compound 2; then compounds 3 and 1 (each within the scatter of the next); then compound 4.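

In this assay the 1-benzothiophen-2-yl group on this carbon between two ring nitrogen atoms gives a 40-fold higher number from compound 2 to compound 4 (1.60 log units; beyond the scatter) when it takes the place of phenyl, the largest step in the series, together with a 5.7-fold higher number from compound 3 to compound 4 (0.76 log units; beyond the scatter) against 4-fluorophenyl and a 4.0-fold higher number from compound 1 to compound 4 (0.60 log units; beyond the scatter) against tert-butyl. An aromatic group at this position is therefore no guarantee of a low number: compound 4, with its two aromatic rings, is the weakest inhibitor of the four, and even the non-aromatic tert-butyl group of compound 1 does better, so the earlier gain from phenyl does not carry over to this larger group. No measurement in hand explains this rise.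

The compounds shown leave open whether the loss follows the second ring, the sulfur or the five-membered ring, a question that a thiophen-2-yl group or a naphthalen-2-yl group at the same place could help to separate. Fluoro is also the only substituent shown on the phenyl ring, so the effect of a chloro or methoxy group there remains unknown.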